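The source may hold more compounds than are shown below. What is called first, only, known or untested is meant among the compounds shown, and "the series" means these compounds.

Measured so far:
Compound 1, `O=C(O)Cn1c(=O)c(Oc2cc(O)cc(O)c2)nc2cc(F)ccc21`: 25.4%
Compound 2, `O=C(O)Cn1c(=O)c(Oc2cc(O)cc(O)c2)nc2ccc(Cl)cc21`: 91.3%
Compound 3, `O=C(O)Cn1c(=O)c(Oc2cc(O)cc(O)c2)nc2cc(Cl)ccc21`: 56.5%

All three compounds were tested in a physicochemical assay, read by spectrophotometry, with a stated time of 240 min, tested at 100 uM; on this read-out lower numbers stand for a weaker effect and higher numbers for a stronger effect at the one concentration tested. Compound 2 gives the highest number of the three: in this assay compound 2 shows 91.3%, compound 3 shows 56.5% and compound 1 shows 25.4%. The difference between the cores of compound 2 and compound 3 is not broken down here; the two contain the same atoms joined differently.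

Compound 1 and compound 3 differ by one change, (fluoro in place of chloro on an aromatic carbon), and this change cost a number 31.1 percentage points lower from compound 3 to compound 1 (beyond the scatter), a drop beyond the usual scatter.

The unmeasured compound 4, `O=C(O)Cn1c(=O)c(Oc2cc(O)cc(O)c2)nc2ccc(F)cc21`, arises from compound 2 by the same change, (fluoro in place of chloro on an aromatic carbon), at a place described in identical words. If the change behaves as it did from compound 3 to compound 1, an expected step of a number 33.3 percentage points lower from compound 2 to compound 4 (beyond the scatter) follows. Compound 4 is therefore expected to land near 58%, within a range from 35% to 85%, resting on compound 2 at 91.3% and on the earlier drop of a number 31.1 percentage points lower from compound 3 to compound 1 (beyond the scatter). Going by the values given here, only one example of the change has been measured, so the expectation is uncertain.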

Compound 4, a percentage reported as activity, at one concentration (the size of the read-out at that concentration, not a potency): 38.2%
Estimate against measurement, compound 4: 19.8 percentage points above; the range from low to high includes it.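

Carried to a second core, the change from chloro to fluoro on an aromatic carbon gave a number 53.1 percentage points lower from compound 2 to compound 4 (beyond the scatter) in this assay and so went the same way as the earlier step, which gave a number 31.1 percentage points lower from compound 3 to compound 1 (beyond the scatter) on the other core. This shows that the direction of the change held in both pairs, with each drop beyond the usual scatter, but two pairs are too few to make a rule for the series, and the two steps do not share one size, so a step measured on one core does not fix the size of the step on another. Nothing here gives a measured reason for the drop in either pair, or for the difference in size between the two steps.

The compounds shown leave open how a bromo, a methyl or an amine in place of the chloro would read in this assay on either core. They also leave open whether the fall from chloro to fluoro belongs to these two halogens alone, a question that a compound carrying a plain hydrogen on that aromatic carbon would help to settle.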